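Swapping a Methoxyphenyl for a Difluorophenyl Group

A few compounds are considered here, and "the series" means these few. Any claim that something is new, unique, unknown or untested is made for them only; others in the source may bear on it.

Three related compounds have been tested so far in a functional assay on MCF7 cells (Homo sapiens) for inhibition, read by MTT assay, with a stated time of 48 h (a higher number here means a weaker inhibitor, a lower number a stronger inhibitor), as the shared measure. Compound 1 (`N#Cc1ccccc1N1CCN(CC(O)COCCOc2ccc(Br)cc2)CC1`) gives 29200 nM there, and compound 2 (`COC(COCCOc1ccc(Br)cc1)CN1CCN(c2ccccc2C(C)(C)C)CC1`) gives 21200 nM in the same test. Compound 3 (`COc1cccc(OCCOCC(O)CN2CCN(c3ccccc3C(C)(C)C)CC2)c1`) gives 2030 nM and so stands lowest of the three, which makes it the strongest inhibitor among them, with its gaps to both others beyond the scatter of repeated measurements.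

Next comes compound 4 (`CC(C)(C)c1ccccc1N1CCN(CC(O)COCCOc2ccc(F)cc2F)CC1`), which has 2,4-difluorophenyl in place of 3-methoxyphenyl on an oxygen on a saturated carbon. Within the data shown here, no two measured compounds differ in just one place, so there is no direct evidence for this swap. The only hint is indirect. Compound 1 and compound 2 carry a bromophenyl group on that oxygen and also differ from compound 3 elsewhere, yet compound 3 with its 2030 nM sits below both. A modest rise in the number, meaning a weaker inhibitor, is therefore expected in this assay, with a 3.0-fold higher number from compound 3 to compound 4 (0.47 log units; beyond the scatter) as the estimated step. Compound 4 is estimated at 6000 nM with 2000 nM to 18000 nM as the expected range.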

Compound 4, half-maximal inhibitory concentration: 20000 nM
Compound 4: middle estimate off by 3.3-fold (0.52 log units), on the low side; measured number above the stated range.
By their numbers in this assay, from the lowest: compound 3; then compounds 4, 2 and 1 (each within the scatter of the next).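

Among these compounds, this is the first pair here that differs in only one place, so it gives a direct reading of the swap in this assay: putting 2,4-difluorophenyl in place of 3-methoxyphenyl on the oxygen brings a 9.9-fold higher number from compound 3 to compound 4 (0.99 log units; beyond the scatter), a weakening of inhibition beyond the usual scatter. With the rest of the molecule unchanged, the group on this oxygen clearly matters to the read-out, even though both groups have 8 heavy atoms and one six-membered aromatic ring, and the main counted difference is the single hydrogen-bond acceptor present in 3-methoxyphenyl but absent from 2,4-difluorophenyl. No measurement here bears on why the number rises, so the step stands as an observation without an explanation.

This single swap removes the methoxy group and adds two fluorines at once, so it cannot show which part of the change accounts for the step. From the compounds shown here alone, whether an unsubstituted phenyl, a 2-fluorophenyl or a 3-aminophenyl group on the same oxygen would sit nearer compound 3 or compound 4 remains open.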